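Biaryl tail variation in the shared core series

The compounds below may be only part of what the source reports. "The series", "measured", "known", "first", "only" and "open" are said of these compounds alone.

Compound 2 `CCOc1cccc(-c2ccc([C@H]3S[C@@H](C)C(=O)Nc4c3c(C)nn4-c3ccccc3C)cc2)c1` stands highest of the two numbers measured in an assay on isolated protein for agonist activity at Bile acid receptor (Homo sapiens), read by AlphaScreen, with a stated time of 30 min (a higher number here means that more compound is needed for the effect, a lower number that less compound is needed), with a reading of 3500 nM; compound 1 `Cc1nn(-c2ccccc2Cl)c2c1C(c1ccc(Oc3ccccc3)cc1)SC(C)C(=O)N2` sits nearby, giving 2700 nM in this assay, the two values lying within the scatter. Compound 3 `COC(=O)c1ccc(-c2ccc([C@H]3S[C@@H](C)C(=O)Nc4c3c(C)nn4-c3ccccc3C)cc2)cc1` carries a single change: 4-(methoxycarbonyl)phenyl in place of 3-ethoxyphenyl on an aromatic carbon. Among the compounds with values here, no measured pair shows this step, so no size or direction can be drawn from the data. The step is expected to stay within the scatter, a 1.2-fold lower number from compound 2 to compound 3 (0.07 log units; within the scatter). Compound 3 is therefore estimated at 3000 nM in this assay, within 1000 nM to 9000 nM.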

Compound 3, half-maximal effective concentration: "not active" (no number reported)
No number was reported for compound 3; no gap can be computed for the estimate.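

Within the data shown here, compound 3 was reported as not active, without a number, so no step from compound 2 can be read, and no measured evidence bears on this result. Whether the 4-(methoxycarbonyl)phenyl tail alone accounts for this result remains open.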